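The compounds below may be only part of what the source reports. "The series", "measured", "known", "first", "only" and "open" are said of these compounds alone.

Among the measured compounds shown here, in a functional assay, read by spectrophotometry, with a stated time of 1 h (a lower number here means a stronger inhibitor, a higher number a weaker inhibitor), compound 1 `Nc1ccccc1/N=C\c1cc(=O)oc2cc(OCc3ccccc3)cc(OCc3ccccc3)c12` gives 624000 nM, the higher of the two exact numbers so far. Compound 2 `Nc1ccccc1/N=C\c1cc(=O)oc2cc(OCc3ccccc3)ccc12` gives 34600 nM, and hydrogen in place of benzyloxy on an aromatic carbon accompanies an 18-fold lower number from compound 1 to compound 2 (1.26 log units; beyond the scatter). For compound 3 `O=c1cc(/C=N\O)c2ccc(OCc3ccccc3)cc2o1`, this assay reports only a limit, > 2000000 nM.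

Compound 4 `O=c1cc(/C=N\Nc2ccccc2)c2c(OCc3ccccc3)cc(OCc3ccccc3)cc2o1` has the same atoms as compound 1, joined differently: anilino in place of 2-aminophenyl on a double-bonded nitrogen. This is anilino in place of 2-aminophenyl on a double-bonded nitrogen. The first measured step concerns another place and so says little here. The closer guide is hydroxy in place of 2-aminophenyl on that kind of nitrogen, which gave an at least 57-fold higher number from compound 2 to compound 3 (1.76 log units; beyond the scatter) and shows that this place can matter greatly. That swap lost the aromatic ring, whereas anilino keeps one, so no clear direction can be expected in this assay. The expected change is small and within the scatter, a 1.2-fold lower number from compound 1 to compound 4 (0.10 log units; within the scatter), though the uncertainty is wide. Compound 4 is estimated at 500000 nM, with an expected range of 120000 nM to 2000000 nM.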

Compound 4, half-maximal inhibitory concentration: 401000 nM
For compound 4 the middle estimate is 1.2-fold (0.10 log units) above the measured one, within the range that was stated.
By their numbers in this assay, from the lowest: compound 2; then compounds 4 and 1 (each within the scatter of the next). At a limit, above all of these: compound 3.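

In this assay, anilino in place of 2-aminophenyl on a double-bonded nitrogen gives a 1.6-fold lower number from compound 1 to compound 4 (0.19 log units; within the scatter), so this pair of groups, made of the same atoms joined differently, cannot be told apart here. The earlier change at this place, an at least 57-fold higher number from compound 2 to compound 3 (1.76 log units; beyond the scatter), had shown that a swap there can matter greatly, whereas this pair shows that not every swap there does. Compound 3 is recorded only as a limit of the assay, so the full size of that earlier step stays unknown: the limit of > 2000000 nM in this assay, at which 1 of the 4 values shown sits.

Going by these compounds, compound 1 and compound 4 both carry two benzyloxy groups, so it remains open whether anilino and 2-aminophenyl would also stay level on the core of compound 2. Also open, on these data alone, is how a smaller group such as methyl, or a phenyl ring bearing a carboxylic acid, would read on that nitrogen.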